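Swapping methylamino for 2,6-dimethylmorpholin-4-yl on a carbonyl carbon

The source may report more compounds than this note shows. Statements on the series, on what has been measured and on what is new or still open speak of the compounds shown alone.

In a functional assay on HepG2 cells (Homo sapiens) for inhibition, read by MTT assay, with a stated time of 120 h (on this read-out higher numbers stand for weaker inhibition and lower numbers for stronger inhibition), the measured compounds are these:
Compound 1 `C/C(=C\c1ccc(NC(=O)Nc2ccc(Cl)c(C(F)(F)F)c2)cc1)C(=O)NC(C)c1ccccc1` gives > 50000 nM as a limit of the assay
Compound 2 `CNC(=O)/C(C)=C/c1ccc(NC(=O)Nc2ccc(Cl)c(C(F)(F)F)c2)cc1` gives 44300 nM as a measured number

For the measured compounds named here, compound 2 at 44300 nM thus holds the only value in this small series that is not a limit. Compound 3 `C/C(=C\c1ccc(NC(=O)Nc2ccc(Cl)c(C(F)(F)F)c2)cc1)C(=O)N1CC(C)OC(C)C1` carries 2,6-dimethylmorpholin-4-yl in place of methylamino on a carbonyl carbon, and the change in full is 2,6-dimethylmorpholin-4-yl in place of methylamino on a carbonyl carbon with the rest of the structure the same. Going by the values given here, one measured step bears on this, methyl in place of 1-phenylethyl on an amide-type nitrogen, which gave an at least 1.1-fold lower number from compound 1 to compound 2 (0.05 log units; that floor lies within the scatter) and starts from a limit, so its true size stays open. Resting on that one step and on compound 2 at 44300 nM as the starting point, no step beyond the scatter is expected in this assay in either direction. A result reported only as a limit would fit as well. The expected step is a 1.0-fold higher number from compound 2 to compound 3 (0.01 log units; within the scatter) on this thin basis. For compound 3 the estimate is 45000 nM with an expected range from 15000 nM to 100000 nM in this read-out.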

Compound 3, half-maximal inhibitory concentration: > 50000 nM
Compound 3 was reported as a limit (the forecaster's own chance of this, stated with the estimate: 55%); middle value at least 1.1-fold (0.04 log units) from the limit.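

In this assay compound 3 gives > 50000 nM, which is a limit of the assay. For the compounds shown here, putting 2,6-dimethylmorpholin-4-yl in place of methylamino on the carbonyl carbon gives an at least 1.1-fold higher number from compound 2 to compound 3 (0.05 log units; that floor lies within the scatter), so this change, like the (1-phenylethyl)amino group of compound 1, yields no measured number, and compound 2 remains the only compound of the three with one. As far as these compounds go, the true size of this step therefore stays open, and the step between the two compounds reported as limits cannot be read, because the values of both rest on the same limit: the limit of > 50000 nM in this assay, at which 2 of the 3 values shown sit.

From the compounds shown here alone, it remains open how a morpholin-4-yl group without the two methyl groups, a dimethylamino group, a plain amino group or a hydroxyl group on this carbonyl carbon would read in this assay. Compound 2 gives 44300 nM, and whether any replacement at this place reaches a number clearly lower than that value, or whether changes elsewhere on the shared core would do so, is also left unanswered.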